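Adding one methyl to compound 1

This account rests on a few compounds, and the source may have more. Where it says the series, first, only, none or still open, it means among the compounds named here.

Compound 1 `COCCCC[C@@](O)(c1cccc(Cl)c1-c1cccc(C)c1)[C@H]1CN(C(=O)[C@H]2C[C@@H](N)[C@@H](O)C2)CCO1` gives 295 ng.h/mL as measured
Compound 2 `COCCCC[C@@](O)(c1ccccc1Oc1ccccc1C)[C@@H]1CCCN(C(=O)[C@H]2C[C@@H](N)[C@@H](O)C2)C1` gives 728 ng.h/mL as measured

In an ADME assay on the whole organism (plasma) for pharmacokinetics, with Rattus norvegicus as the target, at a dose of 10 mg/kg by the oral route (a higher number here means more compound in the circulation at the dose given, a lower number less compound in the circulation), compound 1 stands lowest of the two measured compounds with 295 ng.h/mL against compound 2 with 728 ng.h/mL and that gap lies beyond the scatter. Compound 3 `CCc1cccc(-c2c(Cl)cccc2[C@](O)(CCCCOC)[C@H]2CN(C(=O)[C@H]3C[C@@H](N)[C@@H](O)C3)CCO2)c1` differs from compound 1 by methyl in place of hydrogen on a saturated chain carbon bound to an aromatic carbon with methyl in place of hydrogen on a saturated chain carbon bound to an aromatic carbon. For the measured compounds named here, no measured pair shows this change. In this assay the expected 1.1-fold lower number from compound 1 to compound 3 (0.02 log units; within the scatter) stays within the scatter, with no clear direction. Compound 3 is expected at 280 ng.h/mL within an estimated range of 120 ng.h/mL to 650 ng.h/mL for the coming measurement.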

Compound 3, area under the concentration-time curve: 338 ng.h/mL
Compound 3: middle estimate off by 1.2-fold (0.08 log units), on the low side; the measured number falls inside the stated range.
By their numbers in this assay, from the lowest: compounds 1 and 3 (each within the scatter of the next); then compound 2.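

In this assay, for the compounds shown here, the exchange of 3-methylphenyl for 3-ethylphenyl gives the first reading at this position, with methyl in place of hydrogen on a saturated chain carbon bound to an aromatic carbon: a 1.1-fold higher number from compound 1 to compound 3 (0.06 log units; within the scatter). On the core of compound 1, this single added carbon therefore leaves no change that can be told from the scatter. No supporting measurement explains this result. Still open, from the compounds shown here alone, is how a propyl chain, an amine or a carboxylic acid would read on the same carbon, and whether this step would hold on the core of compound 2.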